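Fluoro for hydrogen on the aryl ring: compound 4 outlook

The source may hold more compounds than are shown below. What is called first, only, known or untested is meant among the compounds shown, and "the series" means these compounds.

Measured compounds:
compound 1 `COc1ccc(OC)c(-c2nc(C(c3ccccc3)c3ccccc3)sc2CC(=O)O)c1`, 80%
compound 2 `O=C(O)Cc1sc(C(c2ccccc2)c2ccccc2)nc1-c1ccc(F)cc1`, 80%
compound 3 `O=C(O)Cc1sc(C(c2ccccc2)c2ccccc2)nc1-c1ccccc1`, 80%

All three were read in an in vitro functional assay on HEK285-7 cells for antagonist activity at prostaglandin D2 receptor 2 (Homo sapiens), read by BRET and beta-arrestin recruitment; on this read-out lower numbers stand for smaller maximal responses and higher numbers for larger maximal responses. Compound 3 stands level with compounds 1 and 2 on maximal response; the step of no change at the digits printed from compound 1 to compound 3 (within the scatter) and the step of no change at the digits printed from compound 2 to compound 3 (within the scatter) both lie within the scatter, as does the step of no change at the digits printed from compound 1 to compound 2 (within the scatter). The aryl ring of the shared core has therefore carried 2,5-dimethoxyphenyl, 4-fluorophenyl and plain phenyl without the maximal response moving beyond the scatter.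

Compound 4 `O=C(O)Cc1sc(C(c2ccccc2)c2ccccc2)nc1-c1cccc(F)c1` differs from compound 3 by fluoro in place of hydrogen on an aromatic carbon. Among the measured compounds shown here, the closest precedent is the step of no change at the digits printed from compound 2 to compound 3 (within the scatter), where fluoro was removed from the same kind of ring with no change beyond the scatter. On that basis the step of no change at the digits printed from compound 3 to compound 4 (within the scatter) is expected to stay within the scatter, with no direction favoured. In this assay compound 4 is estimated at 80%, with a range from 70% to 90%.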

Compound 4, largest response reached (reported as efficacy), in percent of the reference or control that the assay uses: 80%
Compound 4: the middle estimate sits on the measured number at the digits printed, within the range that was stated.
By their numbers in this assay, from the lowest: compounds 1, 2, 3 and 4 (each within the scatter of the next).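

In this assay, fluoro in place of hydrogen at a new place on the ring, meta to a large group, gives no change at the digits printed from compound 3 to compound 4 (within the scatter) and so extends the flat picture to 3-fluorophenyl. Comparing the two single-fluoro rings gives no change at the digits printed from compound 2 to compound 4 (within the scatter), so moving the fluoro from 4-fluorophenyl to 3-fluorophenyl does not separate them on maximal response, and the comparison with the doubly substituted ring gives no change at the digits printed from compound 1 to compound 4 (within the scatter) as well. No supporting data are available to explain this flat read-out.

The aryl substituents shown are limited to fluoro and methoxy, so the effect of an amine, a carboxylic acid or a nitrile on this ring remains open. Also open, going by these compounds, is whether a change elsewhere on the shared core would move the maximal response.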